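This account rests on a few compounds, and the source may have more. Where it says the series, first, only, none or still open, it means among the compounds named here.

Working notes on the series.

For the measured compounds named here, compound 1 `Cc1nn(-c2ncnc3nc[nH]c23)c2c1C(C(=O)NCc1ccccc1)CC(=O)N2` is one of two compounds measured so far in a functional assay on HEK293 cells for agonist activity at G-protein coupled receptor 39 (Homo sapiens), read by scintillation proximity assay and inositol phosphate accumulation, with a stated time of 75 min, in the presence of a further agent that is not named here; a lower number here means that less compound is needed, a higher number that more compound is needed for the effect. In this assay compound 1 gives 5 nM, the lowest of the two numbers. The other measured compound, compound 2 `CC(C)(C)c1cc(C(=O)N/N=C/c2ccc(O)cc2O)[nH]n1`, gives 240 nM in this assay, a higher number than that of compound 1 by a margin beyond the usual scatter. Compound 2 is built on a different framework, so it offers no single-point comparison with compound 1.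

Compound 3 `Cc1nn(-c2ncnc3nc[nH]c23)c2c1C(OC(=O)c1ccc(F)cc1)CC(=O)N2` keeps the shared core of compound 1 and differs from it in one place: ((4-fluorophenyl)carbonyl)oxy in place of benzylcarbamoyl on a saturated ring carbon. The group that leaves carries one hydrogen-bond donor and one acceptor; the group that enters carries no donor and two acceptors, and brings one fluorine. Going by the values given here, no pair of measured compounds shows the effect of such a swap on this framework, so the direction of the step is uncertain. Because compound 1 gives 5 nM, the expected step of a 6.0-fold higher number from compound 1 to compound 3 (0.78 log units; beyond the scatter) for compound 3 is a moderate rise in this assay. Compound 3 is estimated at 30 nM in this assay, with a range of 5 nM to 200 nM.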

Compound 3, half-maximal effective concentration: 4 nM
The estimate for compound 3 lay 7.5-fold (0.88 log units) above the measured number, and the stated range ends above it.
By their numbers in this assay, from the lowest: compounds 3 and 1 (each within the scatter of the next); then compound 2.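

In this assay, putting ((4-fluorophenyl)carbonyl)oxy in place of benzylcarbamoyl on a saturated ring carbon gives a 1.3-fold lower number from compound 1 to compound 3 (0.10 log units; within the scatter), so this position of the shared core accepts both groups without a step beyond the scatter. For the compounds shown here, the two groups match in heavy-atom count and in their six-membered aromatic ring of carbon only, but differ in the link to that ring, and the amide hydrogen of benzylcarbamoyl has no counterpart in the entering group; on this framework, a hydrogen-bond donor in this group is therefore not required for a number at this level. Nothing at hand bears on the reason for this result.

The compounds shown do not separate the contribution of the fluorine from that of the carbonyloxy link, since neither a plain benzoyloxy group nor a group differing only in that link appears at this ring carbon. They also leave open how far this position tolerates groups of another kind, such as a primary amine, a carboxylic acid or a simple methyl group.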